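This account rests on a few compounds, and the source may have more. Where it says the series, first, only, none or still open, it means among the compounds named here.

In a functional assay on L1210 cells (Mus musculus) for inhibition, with a stated time of 96 h (a lower number here means a stronger inhibitor, a higher number a weaker inhibitor), compound 2, `CCNCCCNCCCNCC`, gives 10000 nM. Compound 3, `CCCNCCCNCCCNCCC`, gives 60000 nM, so compound 2 holds the lower of the two numbers, by a gap beyond the scatter. Compound 1, `CCNCCCNCCCN`, reads > 100000 nM, which is a limit of the assay and not a number.

The next compound to be tested in this assay is compound 4, `CCNCCCNCCCCN`. Its difference from compound 2 is aminomethyl in place of ethylamino on a saturated chain carbon, three bonds along the chain from an amine nitrogen.

Among the compounds with values here, only one measured step bears on this exchange, that of ethyl in place of hydrogen on an amine nitrogen. It runs an at least 10-fold lower number from compound 1 to compound 2 (1.00 log units; beyond the scatter), a drop beyond the scatter. Compound 4 loses the ethylamino group, so that step, read in reverse, points toward a weaker inhibitor. Within the data shown here, no measured step covers the rest of the exchange, and compound 4 is not a plain reversal, so a somewhat smaller change than the one seen for compound 2 is expected.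

The estimated change is a 4.0-fold higher number from compound 2 to compound 4 (0.60 log units; beyond the scatter), toward a higher number.

For compound 4 the expected value is 40000 nM, within an estimated range of 10000 nM to 100000 nM.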

Compound 4, half-maximal inhibitory concentration: 4000 nM
Compound 4: middle estimate off by 10-fold (1.00 log units), on the high side, outside the stated range (below it).
By their numbers in this assay, from the lowest: compound 4; then compound 2; then compound 3. At a limit, above all of these: compound 1.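

In this assay, aminomethyl in place of ethylamino on a saturated chain carbon, three bonds along the chain from an amine nitrogen, gives a 2.5-fold lower number from compound 2 to compound 4 (0.40 log units; beyond the scatter), so the ethyl group that went with the lower number in an at least 10-fold lower number from compound 1 to compound 2 (1.00 log units; beyond the scatter) is not needed at this place for a low number. The other exchange at this place, aminomethyl in place of amino, gives an at least 25-fold lower number from compound 1 to compound 4 (1.39 log units; beyond the scatter), which shows that an unsubstituted amine here does not by itself go with a weak inhibitor. The size of that step is only a bound, as compound 1 stands at a limit of the assay and not at a number: the limit of > 100000 nM in this assay, at which 1 of the 4 values shown sits.

The compounds shown cannot separate the part played by the amine's lack of an ethyl group from the part played by the length of the chain that carries it, since both differ between the groups exchanged. As far as these compounds go, how a longer chain such as 3-aminopropyl, a hydroxymethyl group or a carboxylic acid would read at this place remains open, as does whether the same exchange would give a step of similar size on another chain.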